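Removing one carbonyl from a side chain

A few compounds are considered here, and "the series" means these few. Any claim that something is new, unique, unknown or untested is made for them only; others in the source may bear on it.

Compound 1 `Cc1cn([C@@H]2O[C@H](CO[Si](C)(C)C(C)(C)C)[C@@]3(OS(=O)(=O)C=C3NCC(=O)OCc3ccccc3)[C@H]2O[Si](C)(C)C(C)(C)C)c(=O)n(C)c1=O` gives 250000 nM
Compound 2 `COC(=O)C(=O)CNC1=CS(=O)(=O)O[C@@]12[C@@H](CO[Si](C)(C)C(C)(C)C)O[C@@H](n1cc(C)c(=O)n(C)c1=O)[C@@H]2O[Si](C)(C)C(C)(C)C` gives 5570 nM

In a functional assay on CCRF-CEM cells (Homo sapiens) (on this read-out lower numbers stand for higher toxicity in this test and higher numbers for lower toxicity in this test), compound 2 holds the lower of the two numbers (5570 nM). Within the data shown here, the only measured step is a 45-fold lower number from compound 1 to compound 2 (1.65 log units; beyond the scatter), with methoxycarbonyl in place of benzyloxy on a carbonyl carbon.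

Compound 3 `COC(=O)CCNC1=CS(=O)(=O)O[C@@]12[C@@H](CO[Si](C)(C)C(C)(C)C)O[C@@H](n1cc(C)c(=O)n(C)c1=O)[C@@H]2O[Si](C)(C)C(C)(C)C` keeps the shared core and alters the side chain of compound 2 : (methoxycarbonyl)methyl in place of (methoxycarbonyl)carbonyl on a saturated chain carbon bound to an amine nitrogen. In words, (methoxycarbonyl)methyl takes the place of (methoxycarbonyl)carbonyl on a saturated chain carbon bound to an amine nitrogen.

Among the measured compounds shown here, no measured pair shows this exact change, so the evidence is indirect. The (methoxycarbonyl)carbonyl group is present in compound 2 and absent from compound 1, and compound 3 gives it up as well. Part of the large step of a 45-fold lower number from compound 1 to compound 2 (1.65 log units; beyond the scatter) might therefore be lost, though a single step is thin support. The expected change is a 4.5-fold higher number from compound 2 to compound 3 (0.65 log units; beyond the scatter), toward a higher number in this assay but probably short of a full return. For compound 3 the estimated value is 25000 nM (expected range 6000 nM to 120000 nM).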

Compound 3, half-maximal cytotoxic concentration: > 250000 nM
Compound 3 gave a limit, no number; the forecaster's own chance of this, stated with the estimate: 20%; middle value at least 10-fold (1.00 log units) away from the limit.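

In this assay compound 3 gives > 250000 nM, which is a limit of the assay and not a number: the limit of > 250000 nM in this assay, at which 1 of the 3 values shown sits.

Even so, the step is readable in one direction: an at least 44-fold higher number from compound 2 to compound 3 (1.65 log units; beyond the scatter). Compound 3 keeps the shared core and the methyl ester, so the low number of compound 2 is tied to the (methoxycarbonyl)carbonyl group on this saturated chain carbon bound to an amine nitrogen, and a methyl ester on the chain is not enough to bring it about, something the first pair could not show since two features changed together there. The remaining step is a number no lower from compound 1 to compound 3 (the limit leaves the size open) and its size cannot be read.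

Open, going by these compounds, is what the (methoxycarbonyl)carbonyl group needs in order to keep the low number: whether a carboxylic acid or an amide at the end of the chain would serve as well as the methyl ester. Also open, on these data alone, is whether a longer chain carrying the same group would hold the number of compound 2 or lose it.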